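The source may hold more compounds than are shown below. What is called first, only, known or untested is meant among the compounds shown, and "the series" means these compounds.

Measured compounds:
- compound 1, `COc1ccccc1NC(=O)Nc1cccc(CNc2ncnc3ccccc23)c1`, which in a functional assay on HepG2 cells (Homo sapiens) for antiproliferative activity, read by MTT assay (a lower number here means a stronger inhibitor, a higher number a weaker inhibitor), gives 17500 nM
- compound 2, `O=C(Nc1cccc(CNc2ncnc3ccccc23)c1)Nc1cccc(C(F)(F)F)c1`, which in this assay gives 40000 nM
- compound 3, `COc1cc2ncnc(NCc3cccc(NC(=O)Nc4cccc(C)c4)c3)c2cc1OC`, which in this assay gives 21500 nM

Compound 3 sits among these three numbers with no clear separation: its gap to compound 1 and its gap to compound 2 both lie within the scatter of the assay. The step under study leads from compound 3 to compound 4, `COc1cc2ncnc(NCc3cccc(NC(=O)Nc4cccc(C(F)(F)F)c4)c3)c2cc1OC`. The change is trifluoromethyl in place of methyl on an aromatic carbon, which at one bond further out reads 3-methylphenyl to 3-(trifluoromethyl)phenyl.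

For the measured compounds named here, only one measured step bears on this: a 2.3-fold higher number from compound 1 to compound 2 (0.36 log units; beyond the scatter). That step also brings in a 3-(trifluoromethyl)phenyl, though on a different starting group, and it weakened the compound modestly. A similar small loss, or no change beyond the scatter, is therefore expected here. Compound 4 is estimated at 30000 nM, with a range from 12000 nM to 75000 nM, which means an expected step of a 1.4-fold higher number from compound 3 to compound 4 (0.14 log units; within the scatter).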

Compound 4, half-maximal inhibitory concentration: 34200 nM
Beside the measured number, compound 4's estimate is 1.1-fold (0.06 log units) below it; the range from low to high includes it.
By their numbers in this assay, from the lowest: compounds 1, 3, 4 and 2 (each within the scatter of the next, the first and the last beyond it).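

In this assay, the direct exchange of methyl for trifluoromethyl on this aromatic carbon gives a 1.6-fold higher number from compound 3 to compound 4 (0.20 log units; within the scatter), so the assay cannot separate these two groups at this position on the core of compound 3. The earlier step, a 2.3-fold higher number from compound 1 to compound 2 (0.36 log units; beyond the scatter), also brought in a 3-(trifluoromethyl)phenyl, but it replaced a 2-methoxyphenyl on a different core, so it could not show what trifluoromethyl does when only methyl leaves. Nothing shown here gives a measured reason for the size of this step.

As far as these compounds go, whether an amine, a carboxylic acid or a methoxy group on the same aromatic carbon would move the number beyond the scatter remains open. So does the question of whether a 2-methoxyphenyl on the core of compound 3 would differ from the 3-methylphenyl there.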